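This account rests on a few compounds, and the source may have more. Where it says the series, first, only, none or still open, it means among the compounds named here.

Measured in a functional assay on MOLT-4 cells (Homo sapiens) for cytotoxicity, read by CCK-8 assay, with a stated time of 72 h; on this read-out lower numbers stand for stronger inhibition and higher numbers for weaker inhibition:
- compound 1, `C=CCn1c(=O)/c(=C\c2cccc(Cl)c2Cl)[nH]c(=O)/c1=C\c1ccccc1OC`: 1200 nM
- compound 2, `C=CCn1c(=O)/c(=C\c2cc(F)ccc2C)[nH]c(=O)/c1=C\c1ccccc1OC`: 3800 nM

Going by the values given here, compound 2 carries the highest number of the two measured so far; its nearest neighbour is compound 1, and the step of a 3.2-fold higher number from compound 1 to compound 2 (0.50 log units; beyond the scatter) is modest but beyond the scatter. Compound 3, `C=CCn1c(=O)/c(=C\c2ccccc2F)[nH]c(=O)/c1=C\c1ccccc1OC`, is not yet measured in this assay. It differs from compound 2 in one place: 2-fluorophenyl in place of 5-fluoro-2-methylphenyl on a double-bonded chain carbon bound to an aromatic carbon.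

Among the compounds with values here, only one measured step touches this position, the exchange of the aryl group on the double-bonded chain carbon that gives a 3.2-fold higher number from compound 1 to compound 2 (0.50 log units; beyond the scatter). Within the data shown here, that step shows the assay responds modestly to the identity of this aryl group, but neither of the measured aryl groups is the 2-fluorophenyl of compound 3, so no direct precedent for its direction exists. Given the modest size of the one relevant step, the step of a 1.3-fold lower number from compound 2 to compound 3 (0.10 log units; within the scatter) is expected to stay within a comparable margin, with direction uncertain. Compound 3 is therefore estimated at 3000 nM in this assay, with a range of 1100 nM to 8500 nM.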

Compound 3, half-maximal inhibitory concentration: 20000 nM
Compound 3: the middle estimate sits 6.7-fold (0.82 log units) below what was measured; measured number above the stated range.
By their numbers in this assay, from the lowest: compound 1; then compound 2; then compound 3.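

In this assay, the aryl group on the double-bonded chain carbon bound to an aromatic carbon matters more than the first step alone indicated: 2-fluorophenyl in place of 5-fluoro-2-methylphenyl gives a 5.3-fold higher number from compound 2 to compound 3 (0.72 log units; beyond the scatter), and 2-fluorophenyl in place of 2,3-dichlorophenyl gives a 17-fold higher number from compound 1 to compound 3 (1.22 log units; beyond the scatter). Both steps lie beyond the scatter, so compound 3 is the weakest of the three, and among these compounds both aryl groups with two substituents give lower numbers than the group with a single fluorine, with none going against this, though three compounds cannot establish a general rule. Nothing available accounts for this difference between the aryl groups.

Going by these compounds, it remains open whether the higher number of compound 3 follows from the loss of a second substituent or from where the fluorine stands, a question that a plain phenyl, a 2-methylphenyl or a 3-fluorophenyl at the same place would help to separate. Also open, on these data alone, is how far the trend extends to other substituents on this aryl group, such as a methoxy group, an amine or a carboxylic acid.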